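Methoxy to nitro on two cores: inhibition in mice

The source may report more compounds than this note shows. Statements on the series, on what has been measured and on what is new or still open speak of the compounds shown alone.

Compound 1 `COc1ccc(N2CCN(CCCOc3ccc4c(c3)CCC4)CC2)cc1` and compound 2 `O=[N+]([O-])c1ccc(N2CCN(CCCOc3ccc4c(c3)CCC4)CC2)cc1` share one core; compound 3 `COc1cc2c(cc1OCCCN1CCN(c3ccccc3)CC1)CCC2` and compound 4 `O=[N+]([O-])c1cc2c(cc1OCCCN1CCN(c3ccccc3)CC1)CCC2` share another. How the core of compound 1 and the core of compound 3 differ is not broken down here. In a functional assay on the whole organism for inhibition, with Mus musculus as the target, at a dose of 25 mg/kg by the oral route (on this read-out lower numbers stand for less inhibition and higher numbers for more inhibition at the one dose given (going by the name of the read-out)), compound 1 gives 60% and compound 2 gives 0%. The change between them, (nitro in place of methoxy on an aromatic carbon), made the step of a number 60 percentage points lower from compound 1 to compound 2 (beyond the scatter). In this assay compound 3 gives 50%. Compound 4 carries the same kind of change, (nitro in place of methoxy on an aromatic carbon); here the place is part of a fused or bridged system of two rings, ortho to a large group, meta to a fused ring and para to a fused ring, whereas in compound 2 it is para to a large group. The expected step is a number 45 percentage points lower from compound 3 to compound 4 (beyond the scatter), an estimate resting on the step of a number 60 percentage points lower from compound 1 to compound 2 (beyond the scatter). Compound 4 is therefore expected to give 5%, estimated between 0% and 30%.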

Compound 4, a percentage reported as inhibition, in the whole organism at one dose (the size of the read-out at that dose, not a potency): 67%
For compound 4 the middle estimate is 62 percentage points below the measured one, outside the stated range (above it).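

On the core of compound 3, nitro in place of methoxy on an aromatic carbon gives a number 17 percentage points higher from compound 3 to compound 4 (beyond the scatter) in this assay, so the step seen on the core of compound 1 does not carry over to this core. The two steps differ in direction as well as size: the same change on two cores in this assay, a number 60 percentage points lower (beyond the scatter) from compound 1 to compound 2 and a number 17 percentage points higher (beyond the scatter) from compound 3 to compound 4, 77 percentage points apart, beyond the scatter of two such steps. For the compounds shown here, this shows that the effect of the change depends on its setting, but not whether the core or the place of the change is responsible, as the two pairs differ in both and each core supplies only one pair.

Open, from the compounds shown here alone, is whether an amine or a nitrile in place of methoxy would also part ways between the two cores. Also open, going by these compounds, is whether the contrast holds at other doses.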